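The compounds below may be only part of what the source reports. "The series", "measured", "known", "first", "only" and "open" are said of these compounds alone.

Measured in a functional assay on CAPAN-1 cells (Homo sapiens) for antiproliferative activity, with a stated time of 72 h; a lower number here means a stronger inhibitor, a higher number a weaker inhibitor:
- Compound 1 `Nc1ncnn2c([C@@H]3O[C@H](CO)[C@@H](O)[C@H]3O)cc(C#CC3CC3)c12`: 20 nM
- Compound 2 `Nc1ncnn2c([C@@H]3O[C@H](CO)[C@@H](O)[C@H]3O)cc(C#Cc3ccccc3)c12`: 37700 nM
- Compound 3 `Nc1ncnn2c([C@@H]3O[C@H](CO)[C@@H](O)[C@H]3O)cc(-c3ccc(F)cc3F)c12`: 50900 nM

Compound 3 has the highest number of the three, but it cannot be separated from compound 2, since the gap is within the scatter: a 1.4-fold higher number from compound 2 to compound 3 (0.13 log units; within the scatter). The distance to the remaining compound is very large: a 2500-fold higher number from compound 1 to compound 3 (3.41 log units; beyond the scatter).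

The next compound is compound 4 `Nc1ncnn2c([C@@H]3O[C@H](CO)[C@@H](O)[C@H]3O)cc(/C=C/c3ccccc3)c12`, which keeps the shared core and swaps one group, with 2-phenylethenyl in place of 2,4-difluorophenyl on an aromatic carbon. Both the leaving and the entering group hold a six-membered aromatic ring of carbon only. The closest evidence comes from the two measured compounds with such a ring in this place. Exchanging 2-phenylethynyl for 2,4-difluorophenyl made no difference beyond the scatter: a 1.4-fold higher number from compound 2 to compound 3 (0.13 log units; within the scatter). The large jump appears only against the cyclopropyl-bearing compound 1: a 1900-fold higher number from compound 1 to compound 2 (3.28 log units; beyond the scatter). For the measured compounds named here, compound 1 is the one measured compound without such a ring, and compound 4 does not share its group. No step beyond the scatter is therefore expected in this assay, though three compounds are thin support. The expected change is small: a 1.7-fold lower number from compound 3 to compound 4 (0.23 log units; within the scatter). For compound 4 the estimated value is 30000 nM, with an estimated range from 6000 nM to 100000 nM.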

Compound 4, half-maximal inhibitory concentration: 2600 nM
Compound 4: the middle estimate sits 12-fold (1.06 log units) above what was measured; measured number below the stated range.
By their numbers in this assay, from the lowest: compound 1; then compound 4; then compounds 2 and 3 (each within the scatter of the next).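

In this assay, the link that carries the aromatic ring at this place matters, even though compound 2, compound 3 and compound 4 all hold a six-membered aromatic ring of carbon only here. With the 2-phenylethenyl group there is a 15-fold lower number from compound 2 to compound 4 (1.16 log units; beyond the scatter), and the exchange for 2,4-difluorophenyl gives a 20-fold lower number from compound 3 to compound 4 (1.29 log units; beyond the scatter), so having such a ring at this position does not by itself set the number at the level of the first two. The gain still falls well short of the cyclopropyl-bearing group, with a 130-fold higher number from compound 1 to compound 4 (2.11 log units; beyond the scatter), and nothing measured here accounts for the difference between the double-bonded and triple-bonded links.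

The compounds shown leave open whether moving from a triple to a double bond would shift the number in the same direction with cyclopropyl at the end, as in a 2-cyclopropylethenyl group, since only the phenyl-bearing pair compares the two links. They also leave open how a saturated 2-phenylethyl chain, or an amine or fluorine on the ring of the 2-phenylethenyl group, would read in this assay.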